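From dimethoxyphenyl to anilino on the shared core

The source may report more compounds than this note shows. Statements on the series, on what has been measured and on what is new or still open speak of the compounds shown alone.

In a functional assay on HeLa cells (Homo sapiens) for antiproliferative activity, read by MTT assay, with a stated time of 72 h (a higher number here means a weaker inhibitor, a lower number a stronger inhibitor), the measured compounds give these values
- compound 1 `COc1cc(C(=O)c2sc3ccccc3c2-c2ccc(F)cc2)cc(OC)c1OC` gives 3000 nM
- compound 2 `COc1cc(C(=O)c2sc3ccccc3c2-c2ccc(Cl)cc2)cc(OC)c1OC` gives 5200 nM
- compound 3 `COc1ccc(OC)c(-c2c(C(=O)c3cc(OC)c(OC)c(OC)c3)sc3ccccc23)c1` gives 10000 nM

Compound 3 sits in the upper part of this small range: one neighbour lies within the scatter (a 1.9-fold higher number from compound 2 to compound 3 (0.28 log units; within the scatter)) and the other modestly beyond it (a 3.3-fold higher number from compound 1 to compound 3 (0.52 log units; beyond the scatter)). The next structure, compound 4 `COc1cc(C(=O)c2sc3ccccc3c2Nc2ccccc2)cc(OC)c1OC`, brings the change anilino in place of 2,5-dimethoxyphenyl on an aromatic carbon with anilino in place of 2,5-dimethoxyphenyl on an aromatic carbon. The two steps above were made at this same place, and both are small. Chloro in place of fluoro also stays within the scatter (a 1.7-fold higher number from compound 1 to compound 2 (0.24 log units; within the scatter)). For the measured compounds named here, no measured compound carries anilino, so the direction is uncertain. In this assay a modest step toward a lower number is expected (a 3.3-fold lower number from compound 3 to compound 4 (0.52 log units; beyond the scatter)). Compound 4 is estimated at 3000 nM (expected range 600 nM to 12000 nM).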

Compound 4, half-maximal inhibitory concentration: 2700 nM
For compound 4 the middle estimate is 1.1-fold (0.05 log units) above the measured one; the measured number falls inside the stated range.
By their numbers in this assay, from the lowest: compounds 4, 1, 2 and 3 (each within the scatter of the next, the first and the last beyond it).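

The position accepts more than a phenyl ring joined directly to the core: in this assay the anilino group, with its nitrogen link and hydrogen-bond donor, gives a 3.7-fold lower number from compound 3 to compound 4 (0.57 log units; beyond the scatter). Against the halogenated phenyl compounds, the anilino group gives a 1.9-fold lower number from compound 2 to compound 4 (0.28 log units; within the scatter) and a 1.1-fold lower number from compound 1 to compound 4 (0.05 log units; within the scatter), so it matches them rather than surpassing them. No supporting evidence explains these differences.

Going by these compounds, it remains open whether the linking nitrogen and its hydrogen matter in themselves. An N-methylanilino group, a benzylamino group or a 4-fluoroanilino group would help to separate these contributions.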